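Swapping Phenyl for a Hydroxypentyl Chain on the Triazole

The compounds below may be only part of what the source reports. "The series", "measured", "known", "first", "only" and "open" are said of these compounds alone.

Of the compounds shown here, three sharing one core have been tested in an ADME assay on HEK293 cells (Homo sapiens) for cytotoxicity, read by sulforhodamine B assay, with a stated time of 48 h, tested at 10 uM; a lower number here means less inhibition, a higher number more inhibition at the concentration tested (going by the name of the read-out). Compound 1 `COc1nc2ccc(Br)cc2cc1C(c1ccccc1)n1cc(-c2ccccc2)nn1` gives 8.25%. Compound 2 `COc1nc2ccc(Br)cc2cc1C(c1ccccc1)n1cc(CO)nn1` gives 11.5%, and compound 3 `COc1nc2ccc(Br)cc2cc1C(c1ccccc1)n1cc(-c2cccc(F)c2)nn1` gives 6.84%. Compound 1 stands second highest of the three numbers, yet the step of a number 3.3 percentage points higher from compound 1 to compound 2 (within the scatter) and the step of a number 1.4 percentage points lower from compound 1 to compound 3 (within the scatter) both lie within the scatter, so the three values cannot really be told apart.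

Compound 4 `COc1nc2ccc(Br)cc2cc1C(c1ccccc1)n1cc(CCCCCO)nn1` differs from compound 1 in one place: 5-hydroxypentyl in place of phenyl on an aromatic carbon. The measured step that bears most on this change is a number 3.3 percentage points higher from compound 1 to compound 2 (within the scatter), where phenyl on the same aromatic carbon gave way to hydroxymethyl, another group carrying a hydroxyl. The step of a number 4.7 percentage points lower from compound 2 to compound 3 (within the scatter), going back from hydroxymethyl to an aryl group, also stayed within the scatter. Within the data shown here, since none of the measured steps moved the read-out beyond the scatter, no step beyond the scatter is expected here either. For compound 4 the expected step is a number 1.8 percentage points higher from compound 1 to compound 4 (within the scatter). Compound 4 is therefore estimated at 10%, with a range from 0% to 22%.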

Compound 4, a percentage reported as inhibition, at one concentration (the size of the read-out at that concentration, not a potency): 7.96%
For compound 4 the middle estimate is 2 percentage points above the measured one; the range from low to high includes it.
By their numbers in this assay, from the lowest: compounds 3, 4, 1 and 2 (each within the scatter of the next).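

On this aromatic carbon of the five-membered aromatic ring with 3 nitrogen, a chain with no ring, bearing a hydrogen-bond donor and acceptor, can stand in place of phenyl in this assay without leaving the scatter (a number 0.3 percentage points lower from compound 1 to compound 4 (within the scatter)). The steps to the other two compounds also stay within the scatter (a number 1.1 percentage points higher from compound 3 to compound 4 (within the scatter); a number 3.5 percentage points lower from compound 2 to compound 4 (within the scatter)), so aryl groups, hydroxymethyl and 5-hydroxypentyl at this position cannot be told apart in this read-out at the one concentration tested. Nothing available offers an explanation for this flat picture.

Still open, on these data alone, is whether an amine or a carboxylic acid at the end of the chain would move the read-out beyond the scatter. As far as these compounds go, a longer chain, or a pentyl chain without its hydroxyl, remains equally open.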